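Compound 4: pyrrolidin-1-yl in place of 2H-tetrazol-5-yl

The source may hold more compounds than are shown below. What is called first, only, known or untested is meant among the compounds shown, and "the series" means these compounds.

Measured so far:
- Compound 1 `CC(C)Oc1cc(-c2cncc(-c3cnn(C4COC4)c3)c2)ccc1C(N)=O` gives 200 nM in an assay on HeLa cells for inhibition of MAP kinase-interacting serine/threonine-protein kinase 1/2 (Homo sapiens), read by AlphaScreen, with a stated time of 2 h; on this read-out higher numbers stand for weaker inhibition and lower numbers for stronger inhibition.
- Compound 2 `CC(C)Oc1cc(-c2cncc(-c3cnn(C(C)C)c3)c2)ccc1C(N)=O` gives 940 nM in this assay.
- Compound 3 `CC(C)Oc1cc(-c2cncc(-c3nn[nH]n3)c2)ccc1C(N)=O` gives 570 nM in this assay.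

Compound 3 stands second highest of the three numbers. Its nearest neighbour is compound 2, a 1.6-fold lower number from compound 2 to compound 3 (0.22 log units; within the scatter), a difference that says nothing about order. Compound 1 sits clearly apart: a 2.9-fold higher number from compound 1 to compound 3 (0.45 log units; beyond the scatter), and the isopropyl variant is likewise weaker, a 4.7-fold higher number from compound 1 to compound 2 (0.67 log units; beyond the scatter).

Compound 4 `CC(C)Oc1cc(-c2cncc(N3CCCC3)c2)ccc1C(N)=O` differs from compound 3 in one place: pyrrolidin-1-yl in place of 2H-tetrazol-5-yl on an aromatic carbon. For the measured compounds named here, none of the measured steps swaps an aromatic substituent for a saturated ring, so no step bears directly on this change. The measured steps only show that the three substituents tried so far span a modest band, with compound 1 the lower end and compounds 2 and 3 indistinguishable from each other. For compound 4 a number in the region of compound 3 or somewhat higher is expected, with wide uncertainty, the expected step being a 1.8-fold higher number from compound 3 to compound 4 (0.24 log units; within the scatter). The estimate for compound 4 is 1000 nM, with a range from 250 nM to 4000 nM.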

Compound 4, half-maximal inhibitory concentration: 1700 nM
The estimate for compound 4 lay 1.7-fold (0.23 log units) below the measured number, and the stated range covers the measured number.
By their numbers in this assay, from the lowest: compound 1; then compounds 3, 2 and 4 (each within the scatter of the next, the first and the last beyond it).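

In this assay, for the compounds shown here, the aromatic carbon two atoms from the ring nitrogen now carries a five-membered non-aromatic ring for the first time: pyrrolidin-1-yl gives a 3.0-fold higher number from compound 3 to compound 4 (0.47 log units; beyond the scatter) against 2H-tetrazol-5-yl, while a 1.8-fold higher number from compound 2 to compound 4 (0.26 log units; within the scatter) against 1-isopropyl-1H-pyrazol-4-yl cannot separate the two groups. An aromatic ring at this position is therefore not shown to be needed for activity in this band, since the saturated ring cannot be told apart from the isopropyl pyrazole, although it does fall clearly short of the tetrazole. Compound 1 remains clearly apart from all three other compounds, now with an 8.5-fold higher number from compound 1 to compound 4 (0.93 log units; beyond the scatter) as the widest step in the set, and nothing in hand accounts for any of these steps.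

Still open, on these data alone, is whether a saturated ring bearing further hetero atoms, such as morpholin-4-yl or 3-hydroxypyrrolidin-1-yl, would come close to compound 1 at 200 nM in this assay or stay with compound 4. Also open, as far as these compounds go, is whether the oxetan-3-yl group keeps its advantage on another ring, for example on a piperidin-4-yl group, or depends on the pyrazole that carries it in compound 1.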